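This account rests on a few compounds, and the source may have more. Where it says the series, first, only, none or still open, it means among the compounds named here.

Compound 1 `Cc1nc2c3ccccc3ccc2c2nc3c(ccc4ccccc43)c(-c3cccc([N+](=O)[O-])c3)c12` gives 157 ug/mL in a functional assay, with a stated time of 90 s; a higher number here means a weaker inhibitor, a lower number a stronger inhibitor.
Compound 2 `COc1ccc(-c2c3ccc4ccccc4c3nc3c2c(C)nc2c4ccccc4ccc32)cc1` gives 176 ug/mL in this assay.
Compound 3 `Cc1nc2c3ccccc3ccc2c2nc3c(ccc4ccccc43)c(-c3ccccc3Cl)c12` gives 170 ug/mL in this assay.

Compound 3 stands second highest of the three numbers in this assay. Its nearest neighbour is compound 2, with a 1.0-fold lower number from compound 2 to compound 3 (0.02 log units; within the scatter); its furthest is compound 1, with a 1.1-fold higher number from compound 1 to compound 3 (0.03 log units; within the scatter). Neither gap exceeds the scatter, so the three compounds cannot be told apart on these numbers.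

Compound 4 `Cc1ccc(-c2c3ccc4ccccc4c3nc3c2c(C)nc2c4ccccc4ccc32)cc1` is the next member of the series. It differs from compound 3 in one place: 4-methylphenyl in place of 2-chlorophenyl on an aromatic carbon. Every measured step in the series is a swap of the aryl group on this same carbon, and all three are within the scatter: a 1.1-fold higher number from compound 1 to compound 2 (0.05 log units; within the scatter), a 1.1-fold higher number from compound 1 to compound 3 (0.03 log units; within the scatter) and a 1.0-fold lower number from compound 2 to compound 3 (0.02 log units; within the scatter). A 3-nitrophenyl, a 4-methoxyphenyl and a 2-chlorophenyl at this position give indistinguishable numbers. On that basis the step to the 4-methylphenyl is expected to stay within the scatter, a 1.0-fold lower number from compound 3 to compound 4 (0.01 log units; within the scatter). The estimate for compound 4 in this assay is therefore 168 ug/mL, expected to fall between 105 ug/mL and 270 ug/mL.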

Compound 4, half-maximal inhibitory concentration: 192 ug/mL
The estimate for compound 4 lay 1.1-fold (0.06 log units) below the measured number; measured number inside the range.
By their numbers in this assay, from the lowest: compounds 1, 3, 2 and 4 (each within the scatter of the next).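

In this assay, the 4-methylphenyl leaves this position as unresponsive as before: the swap for 2-chlorophenyl gives a 1.1-fold higher number from compound 3 to compound 4 (0.05 log units; within the scatter), methyl in place of methoxy gives a 1.1-fold higher number from compound 2 to compound 4 (0.04 log units; within the scatter), and even the largest step in the series, a 1.2-fold higher number from compound 1 to compound 4 (0.09 log units; within the scatter), stays within the scatter. An aryl group of carbon only therefore cannot be told apart from those carrying a nitro, methoxy or chlorine substituent, so none of these substituents is shown to matter here. Nothing available explains why these swaps make so little difference. Going by these compounds, all four groups are substituted phenyl rings, so it stays open whether an amine, a carboxylic acid or a longer alkyl chain at this carbon would give a step beyond the scatter. On these data alone, the methyl on the shared core is the same in all four compounds, so what a change there would do also stays open.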